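The compounds below may be only part of what the source reports. "The series", "measured", "known", "first", "only" and "open" are said of these compounds alone.

Of the compounds shown here, three sharing one core have been measured in a functional assay on CHO.K1 cells for antagonist activity at prostaglandin D2 receptor 2 (Homo sapiens), read by GTPgammaS binding, with a stated time of 1 h; a higher number here means a weaker inhibitor, a lower number a stronger inhibitor. Compound 1 `Cc1c(Cc2ccc(C(F)(F)F)cc2S(=O)(=O)c2ccccc2)c2c(n1CC(=O)O)CCNC2=O` gives 13 nM. Compound 2 `Cc1c(Cc2ccc(S(C)(=O)=O)cc2)c2c(n1CC(=O)O)CCNC2=O` gives 900 nM. Compound 3 `Cc1c(Cc2ccc(S(=O)(=O)c3ccccc3)cc2)c2c(n1CC(=O)O)CCNC2=O` gives 170 nM. Among these three numbers compound 3 stands second highest: its nearest neighbour is compound 2, whose number is higher, and its furthest is compound 1, whose number is lower by a wide margin.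

Compound 4 `Cc1c(Cc2ccc(S(=O)(=O)Cc3ccccc3)cc2)c2c(n1CC(=O)O)CCNC2=O` has not been measured. It differs from compound 3 in one place: benzyl in place of phenyl on a sulfonyl sulfur. Among the compounds with values here, the only measured step that touches this part of the molecule is the exchange of the group on the sulfonyl sulfur from methyl to phenyl, which brought a 5.3-fold lower number from compound 2 to compound 3 (0.72 log units; beyond the scatter). Within the data shown here, that step shows the group on the sulfonyl sulfur matters, but no measured pair shows what inserting one carbon between the sulfur and the phenyl does. A benzyl group is neither the methyl of compound 2 nor the phenyl of compound 3, so the expected number for compound 4 is placed near that of compound 3, with a wide range; the expected step is a 1.5-fold higher number from compound 3 to compound 4 (0.17 log units; within the scatter). Compound 4 is thus estimated at 250 nM, between 80 nM and 800 nM.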

Compound 4, half-maximal inhibitory concentration: 3 nM
The estimate for compound 4 lay 83-fold (1.92 log units) above the measured number; the whole stated range lies above it.
By their numbers in this assay, from the lowest: compound 4; then compound 1; then compound 3; then compound 2.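

In this assay, the group on the sulfonyl sulfur proves far more sensitive than the methyl-to-phenyl exchange suggested: going from phenylsulfonyl to benzylsulfonyl brings a 57-fold lower number from compound 3 to compound 4 (1.75 log units; beyond the scatter), although the same aromatic ring is present and both groups count no hydrogen-bond donors or acceptors. Set against the methyl group, benzyl brings a 300-fold lower number from compound 2 to compound 4 (2.48 log units; beyond the scatter), whereas phenyl brought only a 5.3-fold lower number from compound 2 to compound 3 (0.72 log units; beyond the scatter), so among these compounds the result depends on how the ring is joined to the sulfur and not simply on a ring being present. Nothing available here explains why this small change has so large an effect.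

As far as these compounds go, it remains open whether a longer chain, such as phenylethyl, would lower the number further or raise it again, and whether a fluorine or a methoxy group on the benzyl ring would be tolerated. Equally open, from the compounds shown here alone, is whether benzyl in place of phenyl on the sulfonyl sulfur of compound 1 would bring a step of similar size.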